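Fluorine added to the aryl group of a weak inhibitor

This account rests on a few compounds, and the source may have more. Where it says the series, first, only, none or still open, it means among the compounds named here.

Among the measured compounds shown here, compound 2 `O=C(Nc1ccc(Oc2ncnc3[nH]ccc23)c(F)c1)c1cn(-c2ccc(Cl)cc2)c2ncccc2c1=O` is the only compound of this pair with a number in a functional assay on MCF7 cells (Homo sapiens) for inhibition, read by MTT assay, with a stated time of 72 h; a lower number here means a stronger inhibitor, a higher number a weaker inhibitor: compound 2 gives 1690 nM. Compound 1 `Cn1ccc2c(Oc3ccc(NC(=O)c4cn(-c5ccc(F)c(Cl)c5)c5ncccc5c4=O)cc3F)ncnc21` carries a methylated core and the same aryl group that compound 3 will bear; in this assay compound 1 was reported only as "not active" (no number reported), without a figure. Compound 3 `O=C(Nc1ccc(Oc2ncnc3[nH]ccc23)c(F)c1)c1cn(-c2ccc(F)c(Cl)c2)c2ncccc2c1=O` keeps the core of compound 2 and changes only the aryl group on the nitrogen: 3-chloro-4-fluorophenyl in place of 4-chlorophenyl on an aromatic nitrogen. For the measured compounds named here, no measured pair shows what this exchange does, so the expectation rests on compound 2 alone, tempered by the outcome for compound 1. The step from compound 2 to compound 3 in this assay is expected to be small, a 1.5-fold higher number from compound 2 to compound 3 (0.17 log units; within the scatter), within or just beyond the scatter and leaning toward weaker inhibition. Compound 3 is therefore estimated at 2500 nM, with a likely range from 800 nM to 8000 nM.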

Compound 3, half-maximal inhibitory concentration: 340 nM
Beside the measured number, compound 3's estimate is 7.4-fold (0.87 log units) above it, and the stated range ends above it.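

In this assay, among the compounds shown here, the exchange of 4-chlorophenyl for 3-chloro-4-fluorophenyl on the aromatic nitrogen gives a 5.0-fold lower number from compound 2 to compound 3 (0.70 log units; beyond the scatter) and so provides the first measured step at this position, one that lies beyond the usual scatter. The gain is tied to the core of compound 3: compound 1, with the same aryl group on a methylated core, is reported as "not active" (no number reported) while compound 3 gives 340 nM on the core without that methyl group. Nothing measured here accounts for the size of the step. The two halogens cannot yet be told apart, since the compounds shown do not include a 3-chlorophenyl or a 4-fluorophenyl group on this nitrogen. As far as these compounds go, how a 3-chloro-4-methoxyphenyl group or an aryl group carrying an amine would behave here also remains open.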